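Replacing 4-hydroxypiperidin-1-yl with 4,4-difluoropiperidin-1-yl

A few compounds are considered here, and "the series" means these few. Any claim that something is new, unique, unknown or untested is made for them only; others in the source may bear on it.

Measured in an ADME assay on microsomes from liver (Mus musculus) for metabolic stability, read by LC-MS, using NADPH, with stated times of 10 min and 30 min, tested at 1 uM (on this read-out lower numbers stand for slow clearance and higher numbers for fast clearance), so far:
- compound 1 `COC(=O)C1=C(CN2CCNCC2)NC(c2nccs2)=NC1(C)c1ccc(F)cc1` gives 39 mL/min/kg here
- compound 2 `COC(=O)C1=C(CN2CCC(O)CC2)NC(c2nccs2)=NC1(C)c1ccc(F)cc1` gives 81 mL/min/kg here

Compound 2 holds the higher of these two numbers. Going by the values given here, compound 3 `COC(=O)C1=C(CN2CCC(F)(F)CC2)NC(c2nccs2)=NC1(C)c1ccc(F)cc1` has 4,4-difluoropiperidin-1-yl in place of 4-hydroxypiperidin-1-yl on a saturated chain carbon bound to a double-bonded ring carbon as its single change. Among the compounds with values here, the one measured step at this place is a 2.1-fold higher number from compound 1 to compound 2 (0.32 log units; beyond the scatter) and it is modest. It involves a different swap, so it offers no direction. No shift beyond the scatter is therefore expected in this assay, and the expected step is a 1.0-fold higher number from compound 2 to compound 3 (0.02 log units; within the scatter) on this reasoning. Compound 3 is estimated at 85 mL/min/kg within an expected range of 45 mL/min/kg to 155 mL/min/kg for this read-out.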

Compound 3, clearance in the Mus musculus assay: 88 mL/min/kg
Estimate against measurement, compound 3: 1.0-fold (0.02 log units) below; the range from low to high includes it.
By their numbers in the Mus musculus assay, from the lowest: compound 1; then compounds 2 and 3 (each within the scatter of the next).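

In the Mus musculus assay, 4,4-difluoropiperidin-1-yl and 4-hydroxypiperidin-1-yl stand level at this place, with a 1.1-fold higher number from compound 2 to compound 3 (0.04 log units; within the scatter), and both stand apart from piperazin-1-yl, with a 2.3-fold higher number from compound 1 to compound 3 (0.35 log units; beyond the scatter). The same swap is far from neutral in a physicochemical assay for solubility, read by HPLC, in phosphate buffer, at pH 6.5 (a lower number here means a less soluble compound, a higher number a more soluble compound), where it gives an at least 590-fold lower number from compound 2 to compound 3 (2.77 log units; beyond the scatter). In the physicochemical assay compound 2 gives 593 ug/mL. In the physicochemical assay compound 3 gives < 1 ug/mL, which is a limit of the assay.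

Still open, going by these compounds, is whether morpholin-4-yl at this place would pair a clearance number nearer that of compound 1 with a solubility number nearer that of compound 2.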